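Chloro for trifluoromethyl on the anilide of compound 3

This account rests on a few compounds, and the source may have more. Where it says the series, first, only, none or still open, it means among the compounds named here.

Measured compounds:
compound 1 `C[C@H](NC(=O)c1cc(Cl)ccc1O)C(=O)Nc1ccc(C(F)(F)F)cc1`: > 12500 nM
compound 2 `C[C@H](NC(=O)c1ccc(Cl)cc1O)C(=O)Nc1ccc(Cl)c(Cl)c1`: > 12500 nM
compound 3 `C[C@H](NC(=O)c1ccc(Cl)cc1O)C(=O)Nc1ccc(C(F)(F)F)cc1`: > 12500 nM

In a functional assay on K562 cells (Homo sapiens) for cytotoxicity, with a stated time of 72 h (on this read-out lower numbers stand for stronger inhibition and higher numbers for weaker inhibition), compound 3 gives > 12500 nM, which is a limit of the assay and not a number. Compound 1 likewise gives only the limit > 12500 nM in this assay. Compound 2 also gives only the limit > 12500 nM in this assay. Within the data shown here, because every value shown sits at the limit of > 12500 nM in this assay, at which 3 of the 3 values shown sit, no step can be read; the single one-place step, a step that the two limits leave unreadable from compound 1 to compound 3, has no readable size. Compound 4 `C[C@H](NC(=O)c1ccc(Cl)cc1O)C(=O)Nc1ccc(Cl)cc1` differs from compound 3 by chloro in place of trifluoromethyl on an aromatic carbon. Among the measured compounds shown here, no measured step bears on this change, so no direction can be taken from the series. Compound 4 is therefore expected to stay at or beyond the limit, with a step that the limit leaves unreadable from compound 3 to compound 4 as the estimated step. Compound 4 is estimated at 20000 nM, within 8000 nM to 60000 nM.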

Compound 4, half-maximal inhibitory concentration: > 10000 nM
Compound 4: a limit, no number (the forecaster's own chance of this, stated with the estimate: 80%); the middle value lies beyond the limit too.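

In this assay compound 4 gives only a limit, as do compound 2 and compound 3, so the steps from compound 2 and compound 3 to compound 4 cannot be read. The compounds shown leave open whether any change to the shared core yields a measurable value in this assay.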